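The source may report more compounds than this note shows. Statements on the series, on what has been measured and on what is new or still open speak of the compounds shown alone.

Compound 2, with the structure `CC(/N=C(\NC#N)Nc1ccncc1)C1CC1`, is the lower of the two numbers recorded so far. In a functional assay on the whole organism (blood, strain Wistar-Okamoto) with Rattus norvegicus as the target, with a stated time of 5 days (a higher number here means that more compound is needed for the effect, a lower number that less compound is needed), compound 2 gives 3 mg/kg, while compound 1, with the structure `CC(C)CC(C)/N=C(\NC#N)Nc1ccncc1`, gives 35 mg/kg. Within the data shown here, the one step that connects them, a 12-fold lower number from compound 1 to compound 2 (1.07 log units; beyond the scatter), is the only measured change, and it turns on the group attached to the saturated chain carbon bound to a double-bonded nitrogen and a saturated chain carbon.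

Compound 3, with the structure `CC(/N=C(\NC#N)Nc1ccncc1)c1ccccc1`, has not yet been measured in this assay. It differs from compound 2 at that same position: phenyl in place of cyclopropyl on a saturated chain carbon bound to a double-bonded nitrogen and a saturated chain carbon. Among the measured compounds shown here, the single measured step bears on it only loosely, since it shows that a change of the group at this carbon can move the number by a large amount, but it does not show which way an aromatic ring will go. Compound 3 is therefore expected to give a number in this assay close to that of compound 2, so that the estimated step of a 1.7-fold higher number from compound 2 to compound 3 (0.22 log units; within the scatter) stays within or near the scatter. For compound 3 the estimate is 5 mg/kg, with a range from 1 mg/kg to 30 mg/kg.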

Compound 3, minimum effective dose: 10 mg/kg
Compound 3: middle estimate off by 2.0-fold (0.30 log units), on the low side, and the stated range covers the measured number.
By their numbers in this assay, from the lowest: compound 2; then compound 3; then compound 1.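

Putting phenyl at the saturated chain carbon bound to a double-bonded nitrogen and a saturated chain carbon shows that the gain seen with cyclopropyl is not unique to that ring, since a 3.5-fold lower number from compound 1 to compound 3 (0.54 log units; beyond the scatter) still places an aromatic ring on the better side of isobutyl in this assay and stays beyond the scatter. The gain is nonetheless not the same for both rings, as a 3.3-fold higher number from compound 2 to compound 3 (0.52 log units; beyond the scatter) shows that replacing the three-membered ring with the six-membered aromatic ring gives back part of it. Among these three compounds, the two bearing a ring at this carbon both have lower numbers than the one bearing isobutyl, and no compound shown goes against that, but nothing here explains the order.

The compounds shown leave open whether a phenyl ring carrying an amine or a carboxylic acid would move the number further in either direction. They also leave open where a cyclobutyl ring, a cyclohexyl ring or a longer straight chain at this same carbon would fall relative to cyclopropyl, phenyl and isobutyl.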